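The compounds below may be only part of what the source reports. "The series", "measured", "known", "first", "only" and "open" are said of these compounds alone.

Within the data shown here, in a functional assay on the whole organism (strain CF-1) for inhibition, with Mus musculus as the target (on this read-out lower numbers stand for an effect already at smaller amounts and higher numbers for an effect only at larger amounts of compound), compound 1, whose structure is `Cc1nnc(CN(C)C)n1-c1ccc(Cl)cc1C(=O)c1ccccc1`, gives 1.1 mg/kg, the lowest of the three numbers so far. Compound 3, `Cc1nnc(CN)n1-c1ccc(Cl)cc1C(O)c1ccccc1`, gives 4 mg/kg in this assay, a gap beyond the scatter, and compound 2, `CN(C)CCn1nc(CN(C)C)n(-c2ccc(Cl)cc2C(=O)c2ccccc2)c1=O`, lies furthest away at 18 mg/kg. Compound 4, `CCNCc1nnc(C)n1-c1ccc(Cl)cc1C(=O)c1ccccc1`, has not yet been tested; it differs from compound 1 by a single change: ethylamino in place of dimethylamino on a saturated chain carbon bound to an aromatic carbon. The move is small, and the shared core is untouched. A modest rise in the number is expected from compound 1 to compound 4, about a 1.8-fold higher number from compound 1 to compound 4 (0.26 log units; within the scatter), partly because compound 3, which also carries a nitrogen without two methyl groups on that carbon, gives 4 mg/kg. Compound 4 is therefore estimated at 2 mg/kg, with a likely range from 0.8 mg/kg to 5 mg/kg.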

Compound 4, dose for half-maximal effect: 0.5 mg/kg
Compound 4: the middle estimate sits 4.0-fold (0.60 log units) above what was measured; measured number outside the range, below it.
By their numbers in this assay, from the lowest: compound 4; then compound 1; then compound 3; then compound 2.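

In this assay, ethylamino in place of dimethylamino on a saturated chain carbon bound to an aromatic carbon gives a 2.2-fold lower number from compound 1 to compound 4 (0.34 log units; beyond the scatter) and so a modest step beyond the scatter. At this position, then, two isomeric amines are told apart, and the one carrying a hydrogen-bond donor has the lower number. Nothing measured here explains the step.

As far as these compounds go, it remains open whether the ethyl chain or the hydrogen-bond donor accounts for the step. Also open, from the compounds shown here alone, is what a propylamino or pyrrolidinyl group would give on that carbon.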